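A few compounds are considered here, and "the series" means these few. Any claim that something is new, unique, unknown or untested is made for them only; others in the source may bear on it.

Compound 1 `COc1cc2oc(-c3cccc(NC(=O)c4cccc(Br)c4)c3)cc(=O)c2c(OC)c1OC` at 10900 nM
Compound 2 `COc1cc2oc(-c3cccc(NC(=O)c4ccc([N+](=O)[O-])cc4)c3)cc(=O)c2c(OC)c1OC` at 18800 nM

Among the measured compounds shown here, in a functional assay on HepG2 cells (Homo sapiens) for inhibition, read by MTT assay (a lower number here means a stronger inhibitor of growth, a higher number a weaker inhibitor of growth), compound 2 stands at 18800 nM and lies within the scatter of compound 1, the only other measured compound. Compound 3 `COc1cc2oc(-c3cccc(NC(=O)c4ccc(C(F)(F)F)cc4)c3)cc(=O)c2c(OC)c1OC` differs from compound 2 by trifluoromethyl in place of nitro on an aromatic carbon, with trifluoromethyl in place of nitro on an aromatic carbon, para to a large group. For the measured compounds named here, one measured step bears on this: a 1.7-fold higher number from compound 1 to compound 2 (0.24 log units; within the scatter), with 4-nitrophenyl in place of 3-bromophenyl on a carbonyl carbon. On that evidence, no change beyond the scatter is expected here. The expected step is a 1.3-fold lower number from compound 2 to compound 3 (0.13 log units; within the scatter). For compound 3 the estimated value is 14000 nM, with an expected range from 6000 nM to 35000 nM.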

Compound 3, concentration for 50% growth inhibition: 61100 nM
Compound 3: the middle estimate sits 4.4-fold (0.64 log units) below what was measured, outside the stated range (above it).
By their numbers in this assay, from the lowest: compounds 1 and 2 (each within the scatter of the next); then compound 3.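

In this assay, trifluoromethyl in place of nitro, para to a large group, gives a 3.3-fold higher number from compound 2 to compound 3 (0.51 log units; beyond the scatter), so this position responds to the group it carries, which the earlier pair had not shown. The change from 3-bromophenyl to 4-(trifluoromethyl)phenyl gives a 5.6-fold higher number from compound 1 to compound 3 (0.75 log units; beyond the scatter), also beyond the scatter. Nothing measured here accounts for either step. The compounds shown leave open how an amine or a carboxylic acid at this position would read. On these data alone, whether a nitrile would stay near nitro also remains open.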